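The compounds below may be only part of what the source reports. "The series", "measured", "known", "first", "only" and "open" are said of these compounds alone.

Of the compounds shown here, three have already been tested in an ADME assay on HepG2 2.2.15 cells (Homo sapiens) for cytotoxicity; a lower number here means that less compound is tolerated, a higher number that more compound is tolerated. Compound 1, `Cc1cc(Br)cc(OC(c2ccc(Cl)cc2)c2cnc(NC(=O)OC(C)(C)C)s2)c1`, gives > 50000 nM, and this value is a limit of the assay rather than a measured number. Compound 2, `COCCCNc1ncc(C(Oc2ccc3cc(Br)ccc3c2)c2ccc(Cl)cc2)s1`, is recorded in this assay as "not toxic" (no number reported). Compound 3, `O=C(Nc1ncc(C(Oc2ccc3cc(Br)ccc3c2)c2ccc(Cl)cc2)s1)C1CCCO1`, is recorded in this assay as "not toxic" (no number reported), again without a single number. So compound 3 stands among compounds that all appear tolerated as far as the assay reaches; the one entry with a figure is the limit of > 50000 nM in this assay, at which 1 of the 3 values shown sits. No two of the three tested compounds differ in only one place, so no measured step can be read from them.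

Compound 4, `O=S(=O)(Nc1ncc(C(Oc2ccc3cc(Br)ccc3c2)c2ccc(Cl)cc2)s1)c1cccs1`, is not yet tested. It differs from compound 3 in one place: (thiophen-2-yl)sulfonyl in place of (oxolan-2-yl)carbonyl on a nitrogen on an aromatic ring. What leaves is a five-membered non-aromatic ring with one hetero atom attached through a carbonyl; what enters is a five-membered aromatic ring with one hetero atom attached through a sulfonyl.

Within the data shown here, with no measured step to lean on, the expectation for this change in this assay is no shift beyond the usual scatter, in either direction. Compound 4 is therefore expected to be tolerated as well, at an estimated 60000 nM, within a range from 20000 nM to 200000 nM, and most likely reported only as a limit.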

Compound 4, half-maximal cytotoxic concentration: "not toxic" (no number reported)
No number was reported for compound 4; the estimate stays without a comparison.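

Compound 4 is recorded as "not toxic" with no number, just as compound 3 is, so no step can be read from compound 3 to compound 4. What the compounds shown leave open is how much of each compound this assay would tolerate, since the only figure among them is a limit: the limit of > 50000 nM in this assay, at which 1 of the 4 values shown sits.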